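The source may hold more compounds than are shown below. What is called first, only, known or untested is meant among the compounds shown, and "the series" means these compounds.

Measured compounds:
- compound 1 `Oc1cccc(-c2cc(-c3cccc(Cl)c3)nc(-c3ccco3)c2)c1` — 2530 nM
- compound 2 `Oc1ccc(-c2cc(-c3cccnc3)nc(-c3cccc(Cl)c3)c2)cc1` — 25700 nM
- compound 3 `Oc1ccc(-c2cc(-c3ccncc3)nc(-c3cccc(Cl)c3)c2)cc1` — "not determined" (no result reported)

In an ADME assay on HEK293 cells (Homo sapiens) for cytotoxicity, read by CCK-8 assay and cell counting, with a stated time of 2 days (on this read-out higher numbers stand for weaker inhibition and lower numbers for stronger inhibition), compound 1 gives 2530 nM, while compound 2 gives 25700 nM; these two differ in more than one place, so nothing is counted between them. Going by these compounds, compound 3 stands without a number: in this assay compound 3 is recorded as "not determined" (no result reported), so its position relative to compound 1 and compound 2 is unknown.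

The step to compound 4 `Oc1ccc(-c2cc(-c3cccc(Cl)c3)nc(-c3ccco3)c2)cc1` is furan-2-yl in place of pyridin-4-yl on an aromatic carbon. Among the compounds with values here, with no number for compound 3, no measured step sets the size of this change, and no expectation of direction can be anchored to it. What remains is that compound 4 shares its furan-2-yl and 3-chlorophenyl groups with compound 1 and its 4-hydroxyphenyl group with compound 2. On that basis compound 4 is expected to land between them, nearer to compound 1, at an estimated 5000 nM with a range from 1500 nM to 20000 nM.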

Compound 4, half-maximal inhibitory concentration: 2880 nM
Compound 4: the middle estimate sits 1.7-fold (0.24 log units) above what was measured, within the range that was stated.
By their numbers in this assay, from the lowest: compounds 1 and 4 (each within the scatter of the next); then compound 2.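

In this assay the aromatic carbon next to the ring nitrogen turns out to matter: furan-2-yl in place of pyridin-3-yl gives a clear change beyond the scatter (an 8.9-fold lower number from compound 2 to compound 4 (0.95 log units; beyond the scatter)), the first measured size for a swap at this position. The hydroxyl group behaves differently, since 4-hydroxyphenyl in place of 3-hydroxyphenyl stays within the scatter (a 1.1-fold higher number from compound 1 to compound 4 (0.06 log units; within the scatter)), so that swap shows no difference on this read-out. The step from pyridin-4-yl to furan-2-yl cannot be read, with no number for compound 3.

Nothing available gives a reason for the size of the furan-2-yl step. Also open, going by these compounds, is how a simple phenyl ring or a short chain ending in an amine would fare at this position, and whether a methoxy group would match the hydroxyl.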